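Methoxy for methyl on compound 2

The compounds below may be only part of what the source reports. "The series", "measured", "known", "first", "only" and "open" are said of these compounds alone.

In a functional assay (HSMC cells, Homo sapiens) for antiproliferative activity, with a stated time of 72 h (a higher number here means a weaker inhibitor, a lower number a stronger inhibitor), compound 2 `COC(=O)CNC(=O)c1ccc(C(=O)NC[C@H]2COc3ccccc3O2)cc1-c1ccccc1C` gives 113000 nM, level with compound 3 `COC(=O)CNC(=O)c1ccc(C(=O)NC[C@@H]2COc3ccccc3O2)cc1-c1ccccc1C` at 89000 nM. Among the measured compounds shown here, the one measured step, a 1.3-fold lower number from compound 2 to compound 3 (0.10 log units; within the scatter), reflects (the fact that compounds 2 and 3 differ only in the configuration as drawn), so it says nothing about changing a group. Compound 1 `COC(=O)[C@H](CCSC)NC(=O)c1ccc(C(=O)NC[C@H]2COc3ccccc3O2)cc1-c1ccccc1OC` gives a higher number, 252000 nM. It carries the 2-methoxyphenyl group but also differs from compound 2 elsewhere, so it cannot isolate that group.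

Compound 4 `COC(=O)CNC(=O)c1ccc(C(=O)NC[C@H]2COc3ccccc3O2)cc1-c1ccccc1OC` changes compound 2 in one place, 2-methylphenyl to 2-methoxyphenyl: methoxy in place of methyl on an aromatic carbon. For the measured compounds named here, no measured step tests this swap alone, so no shift beyond the scatter is expected. The estimated step, a 1.1-fold higher number from compound 2 to compound 4 (0.03 log units; within the scatter), stays within the scatter. For compound 4 the expected value is 120000 nM, with an estimated range of 55000 nM to 260000 nM.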

Compound 4, half-maximal inhibitory concentration: 122000 nM
Compound 4: the middle estimate sits 1.0-fold (0.01 log units) below what was measured; low and high end bracket the measured number.
By their numbers in this assay, from the lowest: compounds 3, 2 and 4 (each within the scatter of the next); then compound 1.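

Methoxy in place of methyl on this aromatic carbon leaves the number within the scatter, a 1.1-fold higher number from compound 2 to compound 4 (0.03 log units; within the scatter), so this swap alone does not shift antiproliferative activity in this assay. With methoxy held in place, hydrogen in place of 2-(methylsulfanyl)ethyl gives a 2.1-fold lower number from compound 1 to compound 4 (0.32 log units; beyond the scatter), which ties the higher number of compound 1 to that chain rather than to methoxy. Nothing given here explains why the swap changes so little.

Going by these compounds, whether an amine or a carboxylic acid on that same aromatic carbon would move the number stays open.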